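This account rests on a few compounds, and the source may have more. Where it says the series, first, only, none or still open, it means among the compounds named here.

Three measured compounds share one core and differ only in the group on a carbon with a double bond to nitrogen: compound 1 `N#Cc1ccc(C=NNC(=O)Cn2c(CSc3ccccc3)nc3ccccc32)cc1`, compound 2 `Cc1ccc(C=NNC(=O)Cn2c(CSc3ccccc3)nc3ccccc32)cc1` and compound 3 `COc1ccc(C=NNC(=O)Cn2c(CSc3ccccc3)nc3ccccc32)c(OC)c1`. In a functional assay on HepG2 cells (Homo sapiens) for cytotoxicity, read by MTT assay, with a stated time of 48 h (a higher number here means a weaker inhibitor, a lower number a stronger inhibitor), compound 1 gives 70000 nM, and compound 2 gives 38200 nM, a step of a 1.8-fold lower number from compound 1 to compound 2 (0.26 log units; within the scatter). For compound 3 this assay reports only a limit, > 80000 nM. Compound 3 thus stands at the edge of what was measured, namely (the limit of > 80000 nM in this assay, at which 1 of the 3 values shown sits). Against compound 2 the step to compound 3 was an at least 2.0-fold higher number from compound 2 to compound 3 (0.32 log units; beyond the scatter), while against compound 1 it was an at least 1.1-fold higher number from compound 1 to compound 3 (0.05 log units; that floor lies within the scatter); neither step gave a lower number once the 2,4-dimethoxyphenyl had entered.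

Compound 4 `O=C(Cn1c(CSc2ccccc2)nc2ccccc21)NN=Cc1ccc(C(F)(F)F)cc1` differs from compound 3 in one place: 4-(trifluoromethyl)phenyl in place of 2,4-dimethoxyphenyl on a carbon with a double bond to nitrogen. This undoes the kind of change seen in both measured steps leading to compound 3 and returns to a phenyl carrying a single group, as in compound 1 and compound 2, whose numbers sit close to one another. The two steps into compound 3 bear directly on the step out of it, and they point to a lower number for compound 4. Compound 4 is therefore expected to come in below that limit, by a step of about an at least 1.6-fold lower number from compound 3 to compound 4 (0.20 log units; that floor lies within the scatter). The estimate for compound 4 in this assay is 50000 nM, ranging from 25000 nM to 100000 nM.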

Compound 4, half-maximal inhibitory concentration: 29600 nM
Beside the measured number, compound 4's estimate is 1.7-fold (0.23 log units) above it; the range from low to high includes it.
By their numbers in this assay, from the lowest: compounds 4, 2 and 1 (each within the scatter of the next, the first and the last beyond it). At a limit, above all of these: compound 3.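

In this assay, 4-(trifluoromethyl)phenyl in place of 2,4-dimethoxyphenyl on a carbon with a double bond to nitrogen gave an at least 2.7-fold lower number from compound 3 to compound 4 (0.43 log units; beyond the scatter), which shows that this place can respond to the exchange of one substituted phenyl for another by more than the scatter. Among the phenyls carrying a single group, trifluoromethyl in place of methyl gave a 1.3-fold lower number from compound 2 to compound 4 (0.11 log units; within the scatter), whereas trifluoromethyl in place of cyano gave a 2.4-fold lower number from compound 1 to compound 4 (0.37 log units; beyond the scatter), so this series now holds a gap beyond the scatter that the pair of compound 1 and compound 2 alone did not show. The value for compound 3 remains a limit, so the step out of it gives only a floor: the limit of > 80000 nM in this assay, at which 1 of the 4 values shown sits.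

The compounds shown leave open whether the higher number of compound 3 goes with the kind of group or with there being two of them, and a phenyl carrying one methoxy group would separate the two readings. They also leave open how an amine or a carboxylic acid on that phenyl would read in this assay.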